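Thiophene for furan: what to expect of compound 4

The source may report more compounds than this note shows. Statements on the series, on what has been measured and on what is new or still open speak of the compounds shown alone.

Among the compounds with values here, in a functional assay on MT2 cells (Homo sapiens) for cytotoxicity, read by MTT assay (a lower number here means that less compound is tolerated, a higher number that more compound is tolerated), three compounds have numbers so far. Compound 1 `CC(C)=CCOc1cc(Nc2nccs2)ccc1C` gives 17000 nM and compound 2 `CC(C)=CCOc1cc(Nc2nccs2)ccc1C(C)C` gives 31000 nM. Compound 3 `N#Cc1ccc(Nc2nccs2)cc1OCc1ccco1` gives 18000 nM and cannot be told apart from the other two, as all the gaps between them lie within the scatter of repeated measurements.

Compound 4 `N#Cc1ccc(Nc2nccs2)cc1OCc1cccs1` has not been measured yet. Its difference from compound 3 is thiophen-2-yl in place of furan-2-yl on a saturated chain carbon bound to an oxygen on an aromatic ring and it sits on a saturated chain carbon bound to an oxygen on an aromatic ring. In words, thiophen-2-yl stands in place of furan-2-yl.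

Within the data shown here, only one measured step exists, and it is a 1.8-fold higher number from compound 1 to compound 2 (0.26 log units; within the scatter) for isopropyl in place of methyl on an aromatic carbon. Among the measured compounds shown here, that is a different change in a different place, so it offers only weak guidance, and no measurement yet tests the swap itself. No step beyond the scatter is therefore expected in this assay and no direction can be favoured. The estimated step is a 1.1-fold higher number from compound 3 to compound 4 (0.02 log units; within the scatter) and it is expected to stay within the scatter. Compound 4 is estimated at 19000 nM with an expected range from 9500 nM to 38000 nM for its measurement.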

Compound 4, half-maximal cytotoxic concentration: 4100 nM
The estimate for compound 4 lay 4.6-fold (0.67 log units) above the measured number; measured number outside the range, below it.
By their numbers in this assay, from the lowest: compound 4; then compounds 1, 3 and 2 (each within the scatter of the next).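

In this assay, within the data shown here, thiophen-2-yl in place of furan-2-yl on a saturated chain carbon bound to an oxygen on an aromatic ring gives a 4.4-fold lower number from compound 3 to compound 4 (0.64 log units; beyond the scatter) and this is the first step in the set that lies beyond the scatter. The two groups match in their count of heavy atoms, in their five-membered aromatic ring with one hetero atom, and in their hydrogen-bond donors and acceptors, and neither carries a net charge, so the change amounts to sulfur taking the place of oxygen in the ring. This position therefore responds in this assay to the exchange of a single ring atom, in the direction of less compound being tolerated, although no measurement at hand explains the drop.

The compounds shown leave open whether a phenyl ring or a thiophen-3-yl group in the same place would keep the number as low as in compound 4 or bring it back towards that of compound 3. They also leave open whether the same swap would lower the number on a core carrying methyl or isopropyl in place of the nitrile, since a single pair cannot show how far this step carries over to other compounds.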